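From Compound 3 to Compound 4: Chloro for Fluoro

The compounds below may be only part of what the source reports. "The series", "measured", "known", "first", "only" and "open" are said of these compounds alone.

Three compounds share one core and differ only in the group on an amine nitrogen in a ring. Compound 1 `Nc1scc(CN2CCN(c3ccncc3)CC2)c1C(=O)c1ccc(Cl)cc1` carries pyridin-4-yl there; in a functional assay on CHO cells with adenosine receptor A1 (Homo sapiens) as the target, read by cAMP accumulation and immunoassay, with a stated time of 6 min, tested at 1 uM (on this read-out lower numbers stand for a stronger effect and higher numbers for a weaker effect at the one concentration tested), compound 1 gives -8.3%. Compound 2 `Nc1scc(CN2CCN(c3cc(F)cc(F)c3)CC2)c1C(=O)c1ccc(Cl)cc1` carries 3,5-difluorophenyl, and in this assay compound 2 gives -66%. Compound 3 `Nc1scc(CN2CCN(c3ccc(F)c(Cl)c3)CC2)c1C(=O)c1ccc(Cl)cc1` carries 3-chloro-4-fluorophenyl; in this assay compound 3 gives -60%. Against compound 1 both phenyl compounds stand far apart: a number 57.7 percentage points lower from compound 1 to compound 2 (beyond the scatter) and a number 51.7 percentage points lower from compound 1 to compound 3 (beyond the scatter). Between the two phenyl compounds the gap is small, a number 6 percentage points higher from compound 2 to compound 3 (within the scatter), so compound 3 and compound 2 cannot be told apart on this read-out, while each lies well beyond compound 1.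

Compound 4 `Nc1scc(CN2CCN(c3ccc(Cl)c(Cl)c3)CC2)c1C(=O)c1ccc(Cl)cc1` differs from compound 3 in one place: chloro in place of fluoro on an aromatic carbon. Among the compounds with values here, no measured step exchanges one halogen for another on the same carbon, so the only bearing comes from a number 6 percentage points higher from compound 2 to compound 3 (within the scatter), where a different halogen pattern on the phenyl group left the read-out within the scatter. On that basis compound 4 is expected to show a number 2 percentage points lower from compound 3 to compound 4 (within the scatter), nothing beyond the scatter. The estimate for compound 4 in this assay is -62%, within -80% to -42%.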

Compound 4, a percentage reported as activity, at one concentration (the size of the read-out at that concentration, not a potency): -60%
For compound 4 the middle estimate is 2 percentage points below the measured one, within the range that was stated.
By their numbers in this assay, from the lowest: compounds 2, 3 and 4 (each within the scatter of the next); then compound 1.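

Within the data shown here, this is the first direct exchange of one halogen for another on a single aromatic carbon, and in this assay it gives no change at the digits printed from compound 3 to compound 4 (within the scatter) as the reading, so at this carbon, ortho to a chloro group and para to a large group, fluoro and chloro cannot be told apart on this read-out. The 3,4-dichlorophenyl group likewise cannot be told apart from the 3,5-difluorophenyl group, with a number 6 percentage points higher from compound 2 to compound 4 (within the scatter) on the same read-out, yet the pyridin-4-yl comparison gives a number 51.7 percentage points lower from compound 1 to compound 4 (beyond the scatter) as its step, so the three halogenated phenyl groups shown stand apart from pyridin-4-yl but not from one another. No measurement at hand gives a reason for any of these steps.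

The compounds shown leave open whether this carbon tolerates something other than a halogen, such as a methoxy group, a nitrile or a carboxylic acid, in the way it tolerates fluoro and chloro. They also leave open whether a phenyl group with no halogen at all would read with the halogenated compounds or with compound 1.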